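Aryl variation on the shared core of compound 3

This account rests on a few compounds, and the source may have more. Where it says the series, first, only, none or still open, it means among the compounds named here.

Largest response in an in vitro functional assay on HEK285-7 cells for antagonist activity at prostaglandin D2 receptor 2 (Homo sapiens), read by BRET and beta-arrestin recruitment (a lower number here means a smaller maximal response, a higher number a larger maximal response), for the measured compounds:
compound 1 `O=C(O)Cc1sc(C(c2ccc(F)cc2)c2ccc(F)cc2)nc1-c1ccnc(N2CCCC2)c1` gives 80%;
compound 2 `O=C(O)Cc1sc(C(c2ccc(F)cc2)c2ccc(F)cc2)nc1-c1cn[nH]c1` gives 80%;
compound 3 `O=C(O)Cc1sc(C(c2ccc(F)cc2)c2ccc(F)cc2)nc1-c1ccoc1` gives 80%.

Compound 3 stands level with compounds 1 and 2: no change at the digits printed from compound 1 to compound 3 (within the scatter) and no change at the digits printed from compound 2 to compound 3 (within the scatter), as does no change at the digits printed from compound 1 to compound 2 (within the scatter). Compound 4 `N#Cc1cc(-c2nc(C(c3ccc(F)cc3)c3ccc(F)cc3)sc2CC(=O)O)ccc1F` differs from compound 3 only at the aromatic carbon of the core that carries the varied ring: 3-cyano-4-fluorophenyl in place of furan-3-yl on an aromatic carbon. All three measured steps exchange the group at this carbon, and none moved the maximal response beyond the scatter. None of them, however, enters a six-membered ring of carbon only, so the expectation rests on the flat pattern alone. The step of no change at the digits printed from compound 3 to compound 4 (within the scatter) is expected to stay within the scatter. Compound 4 is estimated at 80%, between 65% and 95%.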

Compound 4, largest response reached (reported as efficacy), in percent of the reference or control that the assay uses: 80%
For compound 4 middle estimate and measured number coincide at the digits printed; the measured number falls inside the stated range.
By their numbers in this assay, from the lowest: compounds 1, 2, 3 and 4 (each within the scatter of the next).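

With 3-cyano-4-fluorophenyl at this carbon, this assay shows no change at the digits printed from compound 3 to compound 4 (within the scatter) and no change at the digits printed from compound 2 to compound 4 (within the scatter) as well as no change at the digits printed from compound 1 to compound 4 (within the scatter) in the maximal response. The flat pattern at this position therefore extends to a six-membered aromatic ring of carbon only, bearing a nitrile and a fluorine, alongside furan-3-yl, 1H-pyrazol-4-yl and 2-(pyrrolidin-1-yl)pyridin-4-yl. Nothing available explains why the response stays level across these groups. Still open, as far as these compounds go, is whether a group without a ring here, such as a primary amine or a short alkyl chain, would keep the maximal response level.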